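A Benzyloxy for a Phenyl on a Carbonyl Carbon

A few compounds are considered here, and "the series" means these few. Any claim that something is new, unique, unknown or untested is made for them only; others in the source may bear on it.

Of the compounds shown here, three with a shared core have been tested in an ADME assay on BJ cells (Homo sapiens) for cytotoxicity, with a stated time of 72 h (on this read-out higher numbers stand for an effect only at larger amounts of compound and lower numbers for an effect already at smaller amounts), so far. Compound 1 `C=C[C@@](C)(/C=C/c1ccc(OC)cc1)CCC=C(C)C` gives > 36600 nM as a limit of the assay and not a number. Compound 2 `C=C[C@@](C)(/C=C/c1ccc(O)cc1)CCC(O)C(C)(C)O` gives > 36600 nM as a limit as well. Compound 3 `C=C[C@@](C)(/C=C/c1ccc(O)c(/C=C/C(=O)c2ccccc2)c1)CCC=C(C)C` gives > 20000 nM as a limit too, so it has no exact number, just like the other two. Compound 4 `C=C[C@@](C)(/C=C/c1ccc(O)c(/C=C/C(=O)OCc2ccccc2)c1)CCC=C(C)C` carries benzyloxy in place of phenyl on a carbonyl carbon, the change benzyloxy in place of phenyl on a carbonyl carbon that also reads as benzoyl to benzyloxycarbonyl. Among the measured compounds shown here, no measured pair shows this change. The estimated step that the limit leaves unreadable from compound 3 to compound 4 is expected to stay within the usual scatter, in no set direction. For compound 4 the estimate is 25000 nM as the expected value, with an expected range of 10000 nM to 40000 nM for its measurement.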

Compound 4, half-maximal effective concentration: > 36600 nM
Compound 4 gave a limit, no number; the forecaster's own chance of this, stated with the estimate: 70%; middle value at least 1.4-fold (0.16 log units) away from the limit.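

Among the compounds shown here, compound 3 and compound 4 each give only a limit in this assay, not a number, so no step between them can be read. The compounds shown leave open whether benzyloxy in place of phenyl on a carbonyl carbon changes cytotoxicity at all.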